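The compounds below may be only part of what the source reports. "The series", "measured", "known", "first", "only" and "open" are said of these compounds alone.

Compound 1, `CC(=O)N[C@@H]1CCCc2c1cncc2N1C(=O)c2ccc(Cl)cc2[C@@H]1C`: in an assay on cells for inhibition of cytochrome P450 11B2, mitochondrial (Homo sapiens), read by HTRF (on this read-out higher numbers stand for weaker inhibition and lower numbers for stronger inhibition), compound 1 gives 4 nM.
Compound 2, `CCS(=O)(=O)NCc1cncc(N2C(=O)c3ccc(Cl)cc3C2(C)C)c1`: compound 2 gives 92 nM.
Compound 3, `CC[C@H]1c2cc(Cl)ccc2C(=O)N1c1cncc2c1CCC[C@H]2NC(C)=O`: compound 3 gives 97 nM.

Compound 1 and compound 3 share a core and differ only by hydrogen in place of methyl on a saturated chain carbon bound to a saturated ring carbon, which gave a 24-fold lower number from compound 3 to compound 1 (1.38 log units; beyond the scatter). Compound 2 has another core; the difference between the two cores is not broken down here, and the values of compound 2 and compound 3 sit close together. Compound 4, `CC1(C)c2cc(Cl)ccc2C(=O)N1c1cncc(CNS(C)(=O)=O)c1`, not yet measured, is made from compound 2 by hydrogen in place of methyl on a saturated chain carbon bound to a sulfonyl sulfur. This is the same kind of change as that between compound 3 and compound 1, but at a different place: there the methyl left a saturated chain carbon bound to a saturated ring carbon, here a saturated chain carbon bound to a sulfonyl sulfur. Given the large step of a 24-fold lower number from compound 3 to compound 1 (1.38 log units; beyond the scatter), compound 4 is expected to show a 2.0-fold lower number from compound 2 to compound 4 (0.31 log units; beyond the scatter). Going by the values given here, the one precedent lies on another core and at another place, and a smaller step is expected. Compound 4 is estimated at 45 nM in this assay, expected between 10 nM and 150 nM.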

Compound 4, half-maximal inhibitory concentration: 33 nM
Estimate against measurement, compound 4: 1.4-fold (0.13 log units) above; measured number inside the range.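

In this assay, methyl to hydrogen lowers the number on both cores, with a 2.8-fold lower number from compound 2 to compound 4 (0.45 log units; beyond the scatter), but the size of the step does not carry over: the same change on two cores in this assay, a 24-fold lower number (1.38 log units; beyond the scatter) from compound 3 to compound 1 and a 2.8-fold lower number (0.45 log units; beyond the scatter) from compound 2 to compound 4, 8.7-fold (0.94 log units) apart, beyond the scatter of two such steps. The direction therefore holds in both pairs, while the size of the step on one core gives no reliable figure for the other. The change also sits at a different place on each core, so these two pairs cannot separate an effect of the core from an effect of the place, and they set no general rule for the series.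

Still open, from the compounds shown here alone, is how the same change behaves at one and the same place on both cores. Also open, going by these compounds, is whether propylsulfonyl or an amine in place of methylsulfonyl would continue the trend from ethylsulfonyl to methylsulfonyl.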